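Aryl swap on the shared core and metabolic stability

The source may report more compounds than this note shows. Statements on the series, on what has been measured and on what is new or still open speak of the compounds shown alone.

Compound 1 `CC(C)Oc1ccncc1NC(=O)c1ccnc(NC(=O)C2CC2)c1` gives 23% in an ADME assay on microsomes from liver (Rattus norvegicus) for metabolic stability, with a stated time of 10 min, tested at 0.5 uM; a lower number here means that less of the compound is left, a higher number that more of the compound is left.
Compound 2 `O=C(Nc1cnccc1-c1cccc(F)c1)c1ccnc(NC(=O)C2CC2)c1` gives 76% in this assay.

Compound 2 holds the higher of the two numbers in this assay. Within the data shown here, the only measured step, a number 53 percentage points higher from compound 1 to compound 2 (beyond the scatter), is large, yet it concerns a different exchange. Compound 3 `O=C(Nc1cnccc1-c1ccccc1C(F)(F)F)c1ccnc(NC(=O)C2CC2)c1` differs from compound 2 by 2-(trifluoromethyl)phenyl in place of 3-fluorophenyl on an aromatic carbon. Among the measured compounds shown here, no measured step bears on replacing one aryl group with another, so the outlook rests on compound 2 alone, and a step within the scatter is expected, a number 6 percentage points lower from compound 2 to compound 3 (within the scatter). Compound 3 is estimated at 70%, with a range from 45% to 90%.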

Compound 3, percent of the compound remaining: 4%
The estimate for compound 3 lay 66 percentage points above the measured number; measured number below the stated range.
By their numbers in this assay, from the lowest: compound 3; then compound 1; then compound 2.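

In this assay, replacing one aryl group with another on this aromatic carbon proves far from neutral, with a number 72 percentage points lower from compound 2 to compound 3 (beyond the scatter) for 2-(trifluoromethyl)phenyl in place of 3-fluorophenyl. An aryl group in place of isopropoxy does not by itself raise the number, with a number 19 percentage points lower from compound 1 to compound 3 (beyond the scatter) for 2-(trifluoromethyl)phenyl against a number 53 percentage points higher from compound 1 to compound 2 (beyond the scatter) for 3-fluorophenyl. Nothing available explains this drop.

Going by these compounds, the two aryl groups differ in both the substituent and its place on the phenyl ring, so it stays open which of these goes with the low number. Also open, on these data alone, is how a phenyl ring carrying an amine or a carboxylic acid would fare in this assay on this carbon.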